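From an Ester to a Methoxymethyl Group at the Limit

A few compounds are considered here, and "the series" means these few. Any claim that something is new, unique, unknown or untested is made for them only; others in the source may bear on it.

Compound 2 `CCCOC(=O)c1c(C)coc1-c1ccc2c(CC)cccc2c1OC` was tested in a functional assay on KBVIN cells (Homo sapiens) for cytotoxicity, read by MTT assay, with a stated time of 72 h; on this read-out higher numbers stand for an effect only at larger amounts of compound and lower numbers for an effect already at smaller amounts. In this assay compound 2 gives > 10 ug/mL, which is a limit of the assay and not a number. The two other measured compounds stand at the same limit. Compound 1 `CCOc1c(-c2occ(C)c2C(=O)O)ccc2c(CC)cccc12` gives > 10 ug/mL in this assay, again a limit. Compound 3 `CCc1cccc2c(OC)c(-c3occ(C)c3C(=O)On3nnc4ccccc43)ccc12` gives > 10 ug/mL in this assay, also a limit. This is the limit of > 10 ug/mL in this assay, at which 3 of the 3 values shown sit. Among the compounds with values here, the only step between measured compounds that differ in one place, a step that the two limits leave unreadable from compound 2 to compound 3, therefore stays unreadable, and it concerns the group on the oxygen next to the carbonyl rather than the change considered here.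

Compound 4 `CCc1cccc2c(OC)c(-c3occ(C)c3COC)ccc12` has not yet been measured. It differs from compound 2 by methoxymethyl in place of propoxycarbonyl on an aromatic carbon. No measured step bears on this exchange, and the one step shown gives no size to lean on. For compound 4 the value in this assay is expected around 15 ug/mL, with a range from 5 ug/mL to 60 ug/mL. The step that the limit leaves unreadable from compound 2 to compound 4 is thus expected to stay within the scatter, with a high chance that this assay again reports only a limit.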

Compound 4, concentration for half-maximal effect: 8.8 ug/mL
For compound 4 the middle estimate is 1.7-fold (0.23 log units) above the measured one, and the stated range covers the measured number.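

Within the data shown here, at this position, on an aromatic carbon of the five-membered aromatic ring with 1 oxygen, methoxymethyl in place of propoxycarbonyl gives the first reading in this assay that is a number and not a limit, and the change amounts to an at least 1.1-fold lower number from compound 2 to compound 4 (0.05 log units; that floor lies within the scatter). The value of compound 2 is a limit, so this size is only a floor and the real step may be larger. Of the compounds shown, compound 4 alone stands off the limit: the limit of > 10 ug/mL in this assay, at which 3 of the 4 values shown sit.

On these data alone, it remains open whether this reading depends on the oxygen of methoxymethyl or on the absence of the carbonyl of propoxycarbonyl. As far as these compounds go, how a hydroxymethyl group, an aminomethyl group or a longer ethoxymethyl chain would read at this place also stays open.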